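This account rests on a few compounds, and the source may have more. Where it says the series, first, only, none or still open, it means among the compounds named here.

Compound 1 `CCNC(=O)c1cc(Oc2ccc(NC(=O)c3cc4cccnc4n(-c4ccc(Br)cc4F)c3=O)cc2)ccn1`: 2070 nM
Compound 2 `CCNC(=O)c1cc(Oc2ccc(NC(=O)c3cc4cccnc4n(-c4ccc(C(F)(F)F)cc4Cl)c3=O)cc2)ccn1`: 4770 nM

Going by the values given here, in a functional assay on HT-29 cells (Homo sapiens) for antiproliferative activity, read by MTT assay, with a stated time of 72 h (a lower number here means a stronger inhibitor, a higher number a weaker inhibitor), compound 2 gives 4770 nM, the highest of the two numbers; the only measured step, a 2.3-fold higher number from compound 1 to compound 2 (0.36 log units; beyond the scatter), sets the gap to the other value. Compound 3 `CCCNC(=O)c1cc(Oc2ccc(NC(=O)c3cc4cccnc4n(-c4ccc(C(F)(F)F)cc4Cl)c3=O)cc2)ccn1` differs from compound 2 by methyl in place of hydrogen on a saturated chain carbon, two bonds along the chain from an amide-type nitrogen, a small lengthening of the chain at the far end of the molecule. Among the compounds with values here, no measured step touches this chain, so nothing among the numbers speaks for a shift in either direction. The step expected is a 1.0-fold higher number from compound 2 to compound 3 (0.00 log units; within the scatter), nothing beyond the scatter. Compound 3 is therefore estimated at 4800 nM, within 2000 nM to 12000 nM.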

Compound 3, half-maximal inhibitory concentration: 1960 nM
The estimate for compound 3 lay 2.4-fold (0.39 log units) above the measured number; measured number outside the range, below it.
By their numbers in this assay, from the lowest: compounds 3 and 1 (each within the scatter of the next); then compound 2.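

The chain on the amide-type nitrogen turns out to matter in this assay, with a 2.4-fold lower number from compound 2 to compound 3 (0.39 log units; beyond the scatter), from nothing more than ethylamino to propylamino. Going by these compounds alone, the earlier step changed only the group on the aromatic nitrogen, so this is the first sign that the far end of the molecule also moves the number. Nothing measured here explains the shift.

From the compounds shown here alone, whether a butyl chain or a cyclopropyl group in that place would lower the number further remains open. So does whether the same lengthening would act alike with the 4-bromo-2-fluorophenyl group of compound 1.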